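Piperazine in Place of Benzoxazolylsulfanyl: Expected Cytotoxicity

This account rests on a few compounds, and the source may have more. Where it says the series, first, only, none or still open, it means among the compounds named here.

Compound 1 `Cc1ccc2oc(SCC(=O)Nc3ccc(-c4nc(-c5ccccc5)c(-c5ccccc5)n4C)cc3)nc2c1` is the starting point of this comparison. Going by the values given here, in a functional assay on HT-29 cells (Homo sapiens) for cytotoxicity, read by MTT assay, with a stated time of 24 h, tested at 1.6 ug/mL (on this read-out lower numbers stand for a weaker effect and higher numbers for a stronger effect at the one concentration tested), compound 1 gives 15.5%, the lowest of the three numbers measured so far. Compound 2 `Cc1nnc(SCC(=O)Nc2ccc(-c3nc(-c4ccccc4)c(-c4ccccc4)n3C)cc2)s1` gives 39.9% and compound 3 `Cn1c(-c2ccc(NC(=O)CSC3=NCCS3)cc2)nc(-c2ccccc2)c1-c1ccccc1` gives 30.4%. Both are reached from compound 1 by a single change on the sulfur: a number 24.4 percentage points higher from compound 1 to compound 2 (beyond the scatter) and a number 14.9 percentage points higher from compound 1 to compound 3 (beyond the scatter). Between the two of them the step is a number 9.5 percentage points lower from compound 2 to compound 3 (within the scatter).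

Compound 4 `CCN1CCN(CC(=O)Nc2ccc(-c3nc(-c4ccccc4)c(-c4ccccc4)n3C)cc2)CC1` has not yet been measured. It differs from compound 1 in one place: 4-ethylpiperazin-1-yl in place of (5-methyl-1,3-benzoxazol-2-yl)sulfanyl on a saturated chain carbon bound to a carbonyl carbon. The two measured steps from compound 1 both replaced the group on the sulfur with a smaller ring and both raised the read-out beyond the scatter, by a modest amount. Among the compounds with values here, the change to compound 4 goes further, since the sulfanyl link itself leaves and a six-membered non-aromatic ring with 2 hetero atoms enters; no measured pair covers such a change. Resting on the two steps that do exist, a modest rise is expected, a number 14.5 percentage points higher from compound 1 to compound 4 (beyond the scatter). Compound 4 is therefore estimated at 30%, within a range from 10% to 50%.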

Compound 4, a percentage reported as activity, at one concentration (the size of the read-out at that concentration, not a potency): 13.9%
The estimate for compound 4 lay 16.1 percentage points above the measured number, within the range that was stated.
By their numbers in this assay, from the lowest: compounds 4 and 1 (each within the scatter of the next); then compounds 3 and 2 (each within the scatter of the next).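

Swapping the whole (5-methyl-1,3-benzoxazol-2-yl)sulfanyl group for 4-ethylpiperazin-1-yl on a saturated chain carbon bound to a carbonyl carbon leaves the read-out unmoved, with a number 1.6 percentage points lower from compound 1 to compound 4 (within the scatter), so the rise seen with the smaller sulfur-bound rings does not extend to this change. The same piperazine stands clearly under those two rings, with a number 26 percentage points lower from compound 2 to compound 4 (beyond the scatter) and a number 16.5 percentage points lower from compound 3 to compound 4 (beyond the scatter), yet losing the sulfanyl link cannot by itself account for the gap, since compound 1 keeps that link and still lies within the scatter of compound 4. Nothing available explains why the read-out differs among these groups.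

On these data alone, it remains open whether the ring or the link decides the outcome, which a 5-methyl-1,3,4-thiadiazol-2-yl ring attached directly to the chain carbon would help to separate. Also open, as far as these compounds go, is how a morpholine ring, an open-chain diethylamino group, or a piperazine carrying methyl instead of ethyl would compare with compound 4 at this place.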